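The compounds below may be only part of what the source reports. "The series", "measured", "known", "first", "only" and "open" are said of these compounds alone.

Measured in a functional assay on HL-60 cells (Homo sapiens) for inhibition, read by MTT assay, with a stated time of 48 h, tested at 10 uM; a lower number here means less inhibition of growth, a higher number more inhibition of growth at the concentration tested:

- compound 1 `Cc1cc(=O)c2c(O)c(CN3CC(O)CC3C(=O)O)c(O)c([C@H]3CCN(C)C[C@H]3O)c2o1`: 28%
- compound 2 `Cc1cc(=O)c2c(O)c(CN3CCCCC3)c(O)c([C@H]3CCN(C)C[C@H]3O)c2o1`: 32%
- compound 3 `Cc1oc2c([C@H]3CCN(C)C[C@H]3O)c(O)cc(O)c2c(=O)c1C(O)c1ccccc1Br`: 52%

Compound 3 has the highest number of the three, clearly beyond the scatter from both others. Compound 1 and compound 2 lie within the scatter of each other.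

The next compound, compound 4 `CCOc1ccc(Br)c(C(O)c2c(C)oc3c([C@H]4CCN(C)C[C@H]4O)c(O)cc(O)c3c2=O)c1`, differs from compound 3 in one place: ethoxy in place of hydrogen on an aromatic carbon. This puts ethoxy in place of hydrogen on an aromatic carbon, para to the bromo group, so that 2-bromophenyl becomes 2-bromo-5-ethoxyphenyl.

For the measured compounds named here, only one measured step exists, a number 4 percentage points higher from compound 1 to compound 2 (within the scatter). It swaps one ring-bearing group for another on a saturated chain carbon, a different kind of change at a different part of the molecule, so it bears only weakly on this question. It does show one large change of group that left this assay within the scatter. Going by the values given here, no measured compound carries ethoxy, so the data favour no direction.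

The best starting point is therefore compound 3 at 52%, with a wide margin. The expected change is a number 2 percentage points lower from compound 3 to compound 4 (within the scatter), which amounts to no clear shift. The estimate for compound 4 is 50%, with an expected range from 32% to 70%.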

Compound 4, percent growth inhibition at one concentration: 2%
Compound 4: the middle estimate sits 48 percentage points above what was measured, outside the stated range (below it).
By their numbers in this assay, from the lowest: compound 4; then compounds 1 and 2 (each within the scatter of the next); then compound 3.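

Placing ethoxy in place of hydrogen on this aromatic carbon, para to a bromo group, gives a number 50 percentage points lower from compound 3 to compound 4 (beyond the scatter) in this assay. This shows that the position is not open to any change: adding this one group of 3 heavy atoms leaves compound 4 with almost no growth inhibition at the concentration tested, at 2%. For the compounds shown here, the only earlier step, a number 4 percentage points higher from compound 1 to compound 2 (within the scatter), was a much larger swap of groups at a different part of the molecule, yet it stayed within the scatter, so it gave no hint that so small an addition here could matter this much, and no measurement on hand explains why it does.

The compounds shown leave open whether this loss belongs to ethoxy in particular or would follow any group on this carbon, and a hydroxyl, a methoxy or a longer propoxy chain in the same place would help to separate these cases. They also leave open whether ethoxy would have the same effect if a chloro group stood in place of the bromo group.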